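The source may report more compounds than this note shows. Statements on the series, on what has been measured and on what is new or still open speak of the compounds shown alone.

Measured in an ADME assay on microsomes from liver (Homo sapiens) for metabolic stability, with a stated time of 10 min; a lower number here means that less of the compound is left, a higher number that more of the compound is left:
- Compound 1 `CC(=O)N1CCN(C(=O)N2CC[C@](c3ccc(C(OCc4c(F)cccc4C#N)(C(F)(F)F)C(F)(F)F)cc3)(S(=O)(=O)c3ccc(F)cc3)C2)CC1`: 0%
- Compound 2 `Cc1cccc(C)c1COC(c1ccc([C@]2(S(=O)(=O)c3ccc(F)cc3)CCN(C(=O)[C@H]3CC[C@H](C(=O)O)CC3)C2)cc1)(C(F)(F)F)C(F)(F)F`: 89%

Of these two numbers, the higher belongs to compound 2, at 89%. The gap between compound 2 and compound 1 lies well beyond the scatter. Compound 3 `O=C(O)[C@H]1CC[C@H](C(=O)N2CC[C@](c3ccc(C(OCc4c(F)cccc4Cl)(C(F)(F)F)C(F)(F)F)cc3)(S(=O)(=O)c3ccc(F)cc3)C2)CC1` is the next to be read. It keeps the rest of compound 2 and changes one group: 2-chloro-6-fluorophenyl in place of 2,6-dimethylphenyl on a saturated chain carbon bound to an oxygen on a saturated carbon. In words, 2-chloro-6-fluorobenzyl replaces 2,6-dimethylbenzyl. Among the measured compounds shown here, no pair of measured compounds differs in one place only, so the data offer no direct precedent for this change, and the expectation remains loose. The expected step of a number 4 percentage points lower from compound 2 to compound 3 (within the scatter) is a small fall, not beyond the scatter. In this assay, compound 3 is estimated at 85%, with an expected range from 62% to 97%.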

Compound 3, percent of the compound remaining: 100%
The estimate for compound 3 lay 15 percentage points below the measured number, outside the stated range (above it).
By their numbers in this assay, from the lowest: compound 1; then compound 2; then compound 3.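

In this assay, among the compounds shown here, the change from 2,6-dimethylbenzyl to 2-chloro-6-fluorobenzyl gives a number 11 percentage points higher from compound 2 to compound 3 (beyond the scatter), the first comparison here in which only one place differs. At this place, on a saturated chain carbon bound to an oxygen on a saturated carbon, the aromatic ring keeps its count of 8 heavy atoms while two methyl groups give way to a chlorine and a fluorine, and the compound left after the stated time rises rather than falls. Nothing available explains this rise.

Compound 1 differs from compound 2 and compound 3 in more than one place, so the compounds shown do not tell which of its differences goes with its far lower number. They also leave open how 2,6-dichlorobenzyl at this place, or an amine in place of the carboxylic acid, would read.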